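A few compounds are considered here, and "the series" means these few. Any claim that something is new, unique, unknown or untested is made for them only; others in the source may bear on it.

Measured so far:
Compound 1 `Cc1cc2[nH]nc(N)c2c(=O)[nH]1` gives -1% in an assay on isolated protein for inhibition of serine/threonine-protein kinase D2 (Homo sapiens), read by mobility shift assay, tested at 30 uM; on this read-out lower numbers stand for less inhibition and higher numbers for more inhibition at the one concentration tested (going by the name of the read-out).
Compound 2 `Cc1cc2c(c(N)nn2C)c(=O)[nH]1` gives 5% in this assay.
Compound 3 `Cc1cc2c(cn1)c(N)nn2C` gives -3% in this assay.

Among the measured compounds shown here, all three readings sit close to zero, and no pair is separated by more than the usual scatter, so none of the numbers can be called higher or lower than another. Compound 2 and compound 1 differ in one place, (hydrogen in place of methyl on an aromatic nitrogen), and the step of a number 6 percentage points lower from compound 2 to compound 1 (within the scatter). Compound 4 `Cc1cc2[nH]nc(N)c2cn1` is not yet measured; it is made from compound 3 by the same change, (hydrogen in place of methyl on an aromatic nitrogen), in a place described in the same words. The difference between the core of compound 3 and the core of compound 2 is not broken down here. The earlier step of a number 6 percentage points lower from compound 2 to compound 1 (within the scatter) stayed within the scatter, and compound 3 gives -3%. On that basis the step of a number 1 percentage points higher from compound 3 to compound 4 (within the scatter) is expected to be small. Compound 4 is expected to give -2% in this assay, most likely between -12% and 8%.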

Compound 4, a percentage reported as inhibition, at one concentration (the size of the read-out at that concentration, not a potency): 25%
Compound 4: middle estimate off by 27 percentage points, on the low side, outside the stated range (above it).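

Putting hydrogen in place of methyl on the aromatic nitrogen gives a number 28 percentage points higher from compound 3 to compound 4 (beyond the scatter) in this assay. Among the compounds shown here, the size of this step therefore does not carry over from one core to the other: the same change on two cores in this assay, a number 6 percentage points lower (within the scatter) from compound 2 to compound 1 and a number 28 percentage points higher (beyond the scatter) from compound 3 to compound 4, 34 percentage points apart, beyond the scatter of two such steps With only two pairs, this shows that the core can matter, but it gives no rule for a further core and does not identify which part of the core is responsible.

The compounds shown carry only hydrogen or methyl on that nitrogen, so it remains open how an ethyl group or a longer chain there would read. Also open, going by these compounds, is whether an amide in place of the amino group would keep the reading of compound 4, which at one concentration is not a potency.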